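The compounds below may be only part of what the source reports. "The series", "measured", "known", "first", "only" and "open" are said of these compounds alone.

Compound 1 `CC(C)Oc1cccc(-c2ccc(C(=O)N(Cc3cccc(OCCCCCC(=O)O)c3)C(C)C)cc2)c1` gives > 26000 nM in an ADME assay on HEK293 cells (Homo sapiens) for cytotoxicity, read by CellTiter-Glo and resazurin assay, with a stated time of 72 h; on this read-out higher numbers stand for an effect only at larger amounts of compound and lower numbers for an effect already at smaller amounts.
Compound 2 `CCOC(=O)CCCCCOc1cccc(CN(C(=O)c2ccc(-c3cnc(OC)nc3OC)cc2)C(C)C)c1` gives > 26000 nM in this assay.

Both numbers are limits of the assay, not measured values. For compound 2 the value > 26000 nM means only that no cytotoxic effect appeared up to the highest concentration tested. Among the compounds with values here, compound 1 sits at the same limit, and that is all that can be said of the pair: the limit of > 26000 nM in this assay, at which 2 of the 2 values shown sit, so no step between them can be sized.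

Compound 3 `CCOC(=O)CCCCCOc1cccc(CN(C(=O)c2ccc(-c3cccc(OC(C)C)c3)cc2)C(C)C)c1` is not yet measured. It keeps the ester-bearing chain and the shared core of compound 2 and differs from it in one place: 3-isopropoxyphenyl in place of 2,4-dimethoxypyrimidin-5-yl on an aromatic carbon. The group that enters in compound 3 is the same one that compound 1 carries, and compound 1 also reached the limit in this assay.

With both measured neighbours at the limit, no step beyond the scatter is expected in this assay in either direction; the step from compound 2 to compound 3 is expected to be a step that the limit leaves unreadable from compound 2 to compound 3. Compound 3 is therefore estimated at 40000 nM, within 13000 nM to 120000 nM, most likely again reported only as a limit.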

Compound 3, half-maximal effective concentration: > 26000 nM
Compound 3: only a limit was reported; the forecaster's own chance of this, stated with the estimate: 80%; the middle value is on the limit's open side.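

Compound 3 gives > 26000 nM in this assay, which is a limit of the assay and not a measured number. The steps to compound 3 from compound 2 and from compound 1 cannot be read: the limit of > 26000 nM in this assay, at which 3 of the 3 values shown sit.

The compounds shown leave open at what concentration, if any, compound 1, compound 2 and compound 3 would become cytotoxic, and whether they would then differ.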